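Nitro for Chloro on the Pendant Aryl of Compound 3

The compounds below may be only part of what the source reports. "The series", "measured", "known", "first", "only" and "open" are said of these compounds alone.

Among the measured compounds shown here, compound 3, `Clc1ccc(-c2csc3ncnc(N4CCN(c5ccc(Cl)cc5)CC4)c23)cc1`, is one of three compounds measured in a functional assay on MCF7 cells (Homo sapiens) for cytotoxicity, read by sulforhodamine B assay, with a stated time of 48 h; on this read-out lower numbers stand for stronger inhibition and higher numbers for weaker inhibition. Compound 3 gives 42.6 nM and stands second highest of the three numbers. Its nearest neighbour is compound 2, `COc1ccc(N2CCN(c3ncnc4scc(-c5ccc(Cl)cc5)c34)CC2)cc1`, which gives 48.5 nM in this assay. The furthest is compound 1, `O=[N+]([O-])c1ccc(-c2csc3ncnc(NCc4ccccc4)c23)cc1`, which in this assay gives 31.5 nM. Both gaps are within the scatter, so no order among the three can be read.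

The step to compound 4, `O=[N+]([O-])c1ccc(-c2csc3ncnc(N4CCN(c5ccc(Cl)cc5)CC4)c23)cc1`, changes one place: nitro in place of chloro on an aromatic carbon. For the measured compounds named here, the only measured step in the set, a 1.1-fold lower number from compound 2 to compound 3 (0.06 log units; within the scatter), concerns a different place in the molecule and stays within the scatter, and it does not test a chloro-to-nitro exchange. Going by the values given here, compound 1 carries the nitro group that compound 4 gains, but with a different group on the shared core, so its value shows only that a nitro-bearing compound can give a number in the same range as compound 3. Among the compounds with values here, no measured step therefore bears directly on this change, and the step of a 1.2-fold lower number from compound 3 to compound 4 (0.09 log units; within the scatter) is expected to stay within the scatter, if anything toward a slightly lower number. Compound 4 is estimated at 35 nM, with a range from 15 nM to 80 nM.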

Compound 4, half-maximal inhibitory concentration: 54.4 nM
Beside the measured number, compound 4's estimate is 1.6-fold (0.19 log units) below it, and the stated range covers the measured number.
By their numbers in this assay, from the lowest: compounds 1, 3, 2 and 4 (each within the scatter of the next).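

In this assay, replacing chloro with nitro on an aromatic carbon para to a large group gives a 1.3-fold higher number from compound 3 to compound 4 (0.11 log units; within the scatter) and thus shows that, with everything else held constant, this position accepted 3 heavy atoms and 2 hydrogen-bond acceptors in place of a single chlorine without a change beyond the scatter. The earlier compounds shown here could not show this, as compound 1 carries nitro with a different group on the shared core, and the step from compound 2 to compound 3 concerns another place in the molecule. No measurement beyond these numbers bears on this result.

The compounds shown leave open whether any group at this position would produce a step beyond the scatter, for instance an amine, a carboxylic acid or a longer chain in place of chloro or nitro. They also leave open whether the exchange from 4-chlorophenyl to 4-nitrophenyl would read the same with methoxy rather than chloro on the aryl group at the other end of the molecule.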